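The source may hold more compounds than are shown below. What is called first, only, known or untested is meant among the compounds shown, and "the series" means these compounds.

Measured compounds in an ADME assay on MCF-10A cells (Homo sapiens) for cytotoxicity, read by MTT assay, with a stated time of 72 h; a higher number here means a weaker inhibitor of growth, a lower number a stronger inhibitor of growth:

compound 1 `CS/C(=N\C(=O)c1cc2ccccc2s1)NC(=O)c1cc2ccccc2s1`, 5600 nM
compound 2 `O=C(/N=C(/NC(=O)c1cc(-c2ccccc2)nc2ccccc12)[Se]Cc1ccccc1)c1cc(-c2ccccc2)nc2ccccc12`, 45600 nM
compound 3 `CS/C(=N\C(=O)c1cc(-c2ccccc2)nc2ccccc12)NC(=O)c1cc(-c2ccccc2)nc2ccccc12`, 540 nM

Compound 1 and compound 3 rest on different cores; the difference between the two cores is not broken down here. Compound 3 gives the lowest number of the three, compound 1 the second highest, and the gap between them is beyond the scatter. Within the core of compound 3, the change to compound 2 is a group of 8 heavy atoms (7 carbon, 1 selenium; one six-membered aromatic ring of carbon only) in place of a group of 2 heavy atoms (1 carbon, 1 sulfur; no ring), on a carbon with a double bond to nitrogen, and it brought an 84-fold higher number from compound 3 to compound 2 (1.93 log units; beyond the scatter).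

Compound 4 `O=C(/N=C(/NC(=O)c1cc2ccccc2s1)[Se]Cc1ccccc1)c1cc2ccccc2s1` is not yet measured. It differs from compound 1 by a group of 8 heavy atoms (7 carbon, 1 selenium; one six-membered aromatic ring of carbon only) in place of a group of 2 heavy atoms (1 carbon, 1 sulfur; no ring), on a carbon with a double bond to nitrogen, the same kind of change, described in the same words and at a place described in the same words, now made on the core of compound 1. Whether a step of that size carries over from one core to the other rests on a single measured pair, so the earlier step is taken as a guide and the estimate is drawn somewhat toward the measured values rather than copied outright. The expected step is a 27-fold higher number from compound 1 to compound 4 (1.43 log units; beyond the scatter), which rests on an 84-fold higher number from compound 3 to compound 2 (1.93 log units; beyond the scatter). Compound 4 is then expected to give 150000 nM, with a likely range from 40000 nM to 600000 nM. A number this high may fall outside what the assay reports, in which case only a limit would be returned.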

Compound 4, concentration for total growth inhibition: 62900 nM
Compound 4: middle estimate off by 2.4-fold (0.38 log units), on the high side; low and high end bracket the measured number.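

Putting the selenium-bearing group with its six-membered aromatic ring in place of methylsulfanyl gives an 11-fold higher number from compound 1 to compound 4 (1.05 log units; beyond the scatter) in this assay, so the direction seen on the core of compound 3 recurs on the core of compound 1. The direction carries over, but the size does not, and the two steps differ by more than the scatter: the same change on two cores in this assay, an 84-fold higher number (1.93 log units; beyond the scatter) from compound 3 to compound 2 and an 11-fold higher number (1.05 log units; beyond the scatter) from compound 1 to compound 4, 7.5-fold (0.88 log units) apart, beyond the scatter of two such steps These two pairs show that, in this assay, the change raised the number on both cores and that the size of the step depended on the core, but they do not show why the size differs, nor what the change would do on any third core.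

The compounds shown hold only two groups on the carbon with a double bond to nitrogen, and these differ in both the heteroatom and the rest of the group. From the compounds shown here alone, what selenium alone or the aromatic ring alone would do to the number stays open. A sulfur-linked benzyl group and a selenium-linked methyl would separate the two, while an amine or a longer alkyl chain at the same place would show how far the trend extends in this assay.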